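This account rests on a few compounds, and the source may have more. Where it says the series, first, only, none or still open, it means among the compounds named here.

Measured compounds in an ADME assay on a cell-free system (plasma, Rattus norvegicus, strain Sprague-Dawley) for metabolic stability, read by LC-MS, with a stated time of 120 min, tested at 1 uM; a lower number here means that less of the compound is left, a higher number that more of the compound is left:
Compound 1, `CC#CCn1c(N2CCC[C@@H](N)C2)nc2c1c(=O)n(Cc1ccc(Br)cc1C(=O)OCc1oc(=O)oc1C)c(=O)n2C` — in this assay compound 1 gives 2.11%.
Compound 2, `CC#CCn1c(N2CCC[C@@H](N)C2)nc2c1c(=O)n(Cc1ccc(Br)cc1C(=O)OC)c(=O)n2C` — in this assay compound 2 gives 54.2%.

Among the measured compounds shown here, compound 2 is the higher of the two numbers, and the only step measured so far is the one toward it: a number 52.1 percentage points higher from compound 1 to compound 2 (beyond the scatter). That step concerns the ester side of the shared core, where a hydrogen atom replaced a group of 7 heavy atoms.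

Compound 3, `CC#CCn1c(N2CCC[C@@H](N)C2)nc2c1c(=O)n(Cc1ccc(Cl)cc1C(=O)OC)c(=O)n2C`, is not yet measured. It differs from compound 2 in one place: chloro in place of bromo on an aromatic carbon. The bromo group leaves and a chloro group enters on an aromatic carbon of the six-membered ring of carbon only, meta to the methoxycarbonyl group. For the measured compounds named here, no measured step bears on this change; the step from compound 1 to compound 2 altered a different part of the molecule and says nothing about a halogen exchange on the ring. Going by the values given here, with no comparable step in the data, no change beyond the scatter is expected: the estimated step is a number 0.2 percentage points lower from compound 2 to compound 3 (within the scatter). Compound 3 is therefore expected to give about 54%, within a range of 40% to 68%.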

Compound 3, percent of the compound remaining: 65.2%
Estimate against measurement, compound 3: 11.2 percentage points below, and the stated range covers the measured number.
By their numbers in this assay, from the lowest: compound 1; then compound 2; then compound 3.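

The halogen on the aromatic carbon, meta to a methoxycarbonyl group and para to a large group, turns out not to be a silent position in this assay: the exchange of bromo for chloro gives a number 11 percentage points higher from compound 2 to compound 3 (beyond the scatter). The ester side was the only part of the molecule with a measured step until now, at a number 52.1 percentage points higher from compound 1 to compound 2 (beyond the scatter), and the halogen step shows that a change of a single atom on the aromatic ring also registers, although it is much the smaller of the two steps. Nothing in the data accounts for the difference between the two halogens.

Among the compounds shown here, the two halogens give only one comparison at this position, so it remains open whether a fluoro group, a methyl group, a nitrile or a plain hydrogen on the same carbon would continue the rise or reverse it. On these data alone, it is equally open whether chloro in place of bromo would have any comparable effect in the presence of the larger ester of compound 1, whose value of 2.11% lies far lower in this assay.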